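From thiophen-3-yl to 5-methylthiophen-2-yl on the aromatic carbon

The compounds below may be only part of what the source reports. "The series", "measured", "known", "first", "only" and "open" are said of these compounds alone.

Compound 3 `c1ccc(-c2ccsc2)c(OCC2=NCCN2)c1` gives 98% in a functional assay with Alpha-1A adrenergic receptor (Homo sapiens) as the target, read by calcium flux (a higher number here means a larger maximal response, a lower number a smaller maximal response), the second highest of three values. Its nearest neighbour is compound 1 `c1ccc(-c2cnccn2)c(OCC2=NCCN2)c1` with 97%, and the furthest is compound 2 `c1coc(-c2ccccc2OCC2=NCCN2)c1` with 106%; the steps of a number 1 percentage points higher from compound 1 to compound 3 (within the scatter) and a number 8 percentage points lower from compound 2 to compound 3 (within the scatter) both lie within the scatter. Compound 4 `Cc1ccc(-c2ccccc2OCC2=NCCN2)s1` is the next step: 5-methylthiophen-2-yl in place of thiophen-3-yl on an aromatic carbon. Every exchange of one five-membered aromatic ring for another seen so far, namely a number 9 percentage points higher from compound 1 to compound 2 (within the scatter), a number 1 percentage points higher from compound 1 to compound 3 (within the scatter) and a number 8 percentage points lower from compound 2 to compound 3 (within the scatter), stayed within the scatter, so no step beyond the scatter is expected here either, in either direction. For compound 4 the expected step is no change at the digits printed from compound 3 to compound 4 (within the scatter), giving an estimate of 98%, with a range from 86% to 110%.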

Compound 4, largest response reached (reported as maximum), in percent of the reference or control that the assay uses: 97%
For compound 4 the middle estimate is 1 percentage points above the measured one, within the range that was stated.
By their numbers in this assay, from the lowest: compounds 1, 4, 3 and 2 (each within the scatter of the next).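

A methyl group on the five-membered ring, with the ring attached through a different carbon, does not shift the maximal response in this assay: there is a number 1 percentage points lower from compound 3 to compound 4 (within the scatter) and a number 9 percentage points lower from compound 2 to compound 4 (within the scatter) and also no change at the digits printed from compound 1 to compound 4 (within the scatter) here. This place on the six-membered aromatic ring therefore accepts a methylated thiophene as readily as the unsubstituted rings in these compounds. Nothing available explains this outcome.

From the compounds shown here alone, all four compounds carry an aromatic ring here, so it remains open whether an amine, a carboxylic acid or a longer chain would keep this response.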